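Urea analogue in the antiproliferative series

The source may hold more compounds than are shown below. What is called first, only, known or untested is meant among the compounds shown, and "the series" means these compounds.

The series shares one core, seen in compound 1 `O=C(Nc1cccc(-c2cnc3c(NC(=O)c4cc(Cl)cc(Cl)c4)nccn23)c1)c1ccc(Cl)c(C(F)(F)F)c1` and compound 2 `O=C(Nc1cccc(-c2cnc3c(NC(=O)c4cc(Cl)cc(Cl)c4)nccn23)c1)Nc1ccc(F)cc1F`. In a functional assay on PC-9 cells (Homo sapiens) for antiproliferative activity, read by CellTiter-Glo, with a stated time of 72 h (on this read-out higher numbers stand for weaker inhibition and lower numbers for stronger inhibition), compound 1 gives 3610 nM. In this assay compound 2 gives 2770 nM, the lowest of the two numbers shown, and the step of a 1.3-fold lower number from compound 1 to compound 2 (0.12 log units; within the scatter) stays within the scatter, so the two cannot be ranked. Compound 3 `O=C(Nc1cccc(-c2cnc3c(NC(=O)c4cc(Cl)cc(Cl)c4)nccn23)c1)Nc1ccc(Cl)c(C(F)(F)F)c1` is not yet measured. It differs from compound 2 in one place: 4-chloro-3-(trifluoromethyl)phenyl in place of 2,4-difluorophenyl on an amide-type nitrogen, so that the (4-chloro-3-(trifluoromethyl)phenyl)amino group takes the place of (2,4-difluorophenyl)amino. Among the measured compounds shown here, the only measured step bearing on this is a 1.3-fold lower number from compound 1 to compound 2 (0.12 log units; within the scatter), which exchanged both the aryl group and the link to the carbonyl at once and changed nothing beyond the scatter; no step isolates the aryl exchange on an amide-type nitrogen. For the measured compounds named here, the aryl group entering compound 3 is the one present in compound 1 at 3610 nM. On this basis the expected step in this assay is a 1.1-fold higher number from compound 2 to compound 3 (0.05 log units; within the scatter), with no change beyond the scatter anticipated in either direction. Compound 3 is therefore estimated at 3100 nM, within a range of 1200 nM to 8000 nM.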

Compound 3, half-maximal inhibitory concentration: 11600 nM
Estimate against measurement, compound 3: 3.7-fold (0.57 log units) below; the measured number lies above the stated range.
By their numbers in this assay, from the lowest: compounds 2 and 1 (each within the scatter of the next); then compound 3.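

In this assay the exchange of 2,4-difluorophenyl for 4-chloro-3-(trifluoromethyl)phenyl on an amide-type nitrogen gives a 4.2-fold higher number from compound 2 to compound 3 (0.62 log units; beyond the scatter), which isolates the aryl group at this position and shows that its identity matters here, something the earlier step, with aryl group and link exchanged together, could not show. The same aryl group also responds to its link: placing (4-chloro-3-(trifluoromethyl)phenyl)amino where 4-chloro-3-(trifluoromethyl)phenyl stood on a carbonyl carbon gives a 3.2-fold higher number from compound 1 to compound 3 (0.51 log units; beyond the scatter), so this aryl group alone does not set the number, and compound 3 stands beyond the scatter of both other compounds, though both steps are modest. No measurement at hand bears on the reason for either step.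

Open, from the compounds shown here alone, is how 2,4-difluorophenyl behaves when attached directly to the carbonyl carbon, which would show whether the link matters for that aryl group as well. Also open is whether the trend among these three compounds extends to other groups on the same nitrogen, such as a plain phenyl or a piperidine.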